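A few compounds are considered here, and "the series" means these few. Any claim that something is new, unique, unknown or untested is made for them only; others in the source may bear on it.

In a functional assay on HCT-116 cells (Homo sapiens) for inhibition, read by MTT assay, with a stated time of 72 h (on this read-out higher numbers stand for weaker inhibition and lower numbers for stronger inhibition), compound 1, whose structure is `CCOC(=O)c1oc2ccc(NS(=O)(=O)c3ccc(C(F)(F)F)cc3)cc2c1C`, gives 5030 nM. Compound 2, whose structure is `CCOC(=O)c1oc2ccc(N(Cc3ccccc3)S(=O)(=O)c3ccc([N+](=O)[O-])cc3)cc2c1C`, carries a benzyl group on the sulfonamide nitrogen and a nitro group on the arylsulfonyl ring. In this assay compound 2 reaches only a limit, > 40000 nM, and no number beyond it is known. This is the case described by the limit of > 40000 nM in this assay, at which 1 of the 2 values shown sits, so the step onward from compound 2 can only be judged against that limit. Compound 3, whose structure is `CCOC(=O)c1oc2ccc(N(Cc3ccccc3)S(=O)(=O)c3ccccc3)cc2c1C`, differs from compound 2 by hydrogen in place of nitro on an aromatic carbon. Going by the values given here, with compound 2 sitting at a limit, no measured step tells how far this change moves the read-out. Compound 3 is expected to give roughly 30000 nM, with a range from 8000 nM to 80000 nM. The step of an at least 1.3-fold lower number from compound 2 to compound 3 (0.12 log units; that floor lies within the scatter) is therefore expected to be small or absent, and a limit again is quite possible.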

Compound 3, half-maximal inhibitory concentration: > 40000 nM
Compound 3 gave a limit, no number; the forecaster's own chance of this, stated with the estimate: 50%; at least 1.3-fold (0.12 log units) between middle value and limit.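

In this assay, going by these compounds alone, compound 2 and compound 3 both stand at a limit, so no step between them can be read: the limit of > 40000 nM in this assay, at which 2 of the 3 values shown sit. The compounds shown leave open how far hydrogen in place of nitro on an aromatic carbon moves the read-out, if it moves it at all.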